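Acetyl on the ring nitrogen: from compound 3 to compound 4

The source may report more compounds than this note shows. Statements on the series, on what has been measured and on what is new or still open speak of the compounds shown alone.

Among the compounds with values here, compound 3 `Cc1ccc(NC(=O)c2ccc3c(c2)OCCO3)cc1-c1ccnc2c(N)cccc12` holds the lowest number so far in a functional assay on A375P cells (Homo sapiens) for antiproliferative activity, read by MTT assay, with a stated time of 48 h; on this read-out higher numbers stand for weaker inhibition and lower numbers for stronger inhibition: compound 3 gives 280 nM. Compound 1 `Nc1cccc2c(-c3cccc(NC(=O)c4ccc5c(c4)OCCO5)c3)ccnc12` carries hydrogen where compound 3 carries methyl on an aromatic carbon; compound 1 gives 860 nM, and compound 2 `CC(=O)Nc1cccc2c(-c3cccc(NC(=O)c4ccc5c(c4)OCCO5)c3)ccnc12` gives 570 nM. The step of a 3.1-fold lower number from compound 1 to compound 3 (0.49 log units; beyond the scatter) is modest but beyond the scatter, and compound 3 also stands beyond the scatter from compound 2, so among these three compound 3 is the most potent.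

Compound 4 `CC(=O)Nc1cccc2c(-c3cc(NC(=O)c4ccc5c(c4)OCCO5)ccc3C)ccnc12` differs from compound 3 by acetyl in place of hydrogen on a nitrogen on an aromatic ring. The same change has been seen once on this series, as a 1.5-fold lower number from compound 1 to compound 2 (0.18 log units; within the scatter), a shift that stays within the scatter. The step expected here, a 1.3-fold lower number from compound 3 to compound 4 (0.12 log units; within the scatter), is therefore small and tilted towards a slightly lower number, because a 1.5-fold lower number from compound 1 to compound 2 (0.18 log units; within the scatter) went that way without clearing the scatter. Compound 4 is thus expected to give about 210 nM, with a likely range from 90 nM to 480 nM.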

Compound 4, half-maximal inhibitory concentration: 250 nM
For compound 4 the middle estimate is 1.2-fold (0.08 log units) below the measured one, within the range that was stated.
By their numbers in this assay, from the lowest: compounds 4 and 3 (each within the scatter of the next); then compounds 2 and 1 (each within the scatter of the next).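

In this assay, acetyl in place of hydrogen on the nitrogen can now be read on a second core, a 1.1-fold lower number from compound 3 to compound 4 (0.05 log units; within the scatter), and on both cores the change stays within the scatter: the same change on two cores in this assay, a 1.5-fold lower number (0.18 log units; within the scatter) from compound 1 to compound 2 and a 1.1-fold lower number (0.05 log units; within the scatter) from compound 3 to compound 4, 1.3-fold (0.13 log units) apart, within the scatter of two such steps

The methyl step also repeats when the acetyl group is present, a 2.3-fold lower number from compound 2 to compound 4 (0.36 log units; beyond the scatter), and the two readings agree: the same change on two cores in this assay, a 3.1-fold lower number (0.49 log units; beyond the scatter) from compound 1 to compound 3 and a 2.3-fold lower number (0.36 log units; beyond the scatter) from compound 2 to compound 4, 1.3-fold (0.13 log units) apart, within the scatter of two such steps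

Across these four compounds, then, methyl in place of hydrogen on the aromatic carbon lowers the number beyond the scatter whether the nitrogen carries hydrogen or acetyl, while acetyl gives no step beyond the scatter on either core.

The compounds shown leave open what a benzoyl or a methanesulfonyl group on this nitrogen would do. They also leave open whether an ethyl group or a chlorine atom in place of the methyl would give a step of similar size.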